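A few compounds are considered here, and "the series" means these few. Any claim that something is new, unique, unknown or untested is made for them only; others in the source may bear on it.

Compound 1 `COc1ccc(/C=N/Nc2nc3ccccc3nc2Cc2ccccc2)cc1OC`, measured in an assay on isolated protein for inhibition of Amine oxidase [flavin-containing] A (Homo sapiens), read by spectrophotometry (on this read-out lower numbers stand for stronger inhibition and higher numbers for weaker inhibition), gives 56 nM.
Compound 2 `C/C(=N\Nc1nc2ccccc2nc1Cc1ccccc1)c1ccccc1` gives 79 nM in the same assay.

Only these two numbers are known, and compound 2 sits alongside compound 1, the gap between them within the usual scatter, so neither can be called stronger. Compound 3 `Oc1ccc(/C=N/Nc2nc3ccccc3nc2Cc2ccccc2)cc1` differs from compound 2 in one place: a group of 9 heavy atoms (7 carbon, 1 nitrogen, 1 oxygen; one six-membered aromatic ring of carbon only) in place of a group of 9 heavy atoms (8 carbon, 1 nitrogen; one six-membered aromatic ring of carbon only), on a nitrogen on an aromatic ring. Within the data shown here, no measured pair shows the effect of such a swap here, so the expected step is small and of uncertain direction, not beyond the scatter. Compound 3 is therefore expected to give about 55 nM in this assay, plausibly anywhere from 20 nM to 150 nM, a shift of a 1.4-fold lower number from compound 2 to compound 3 (0.16 log units; within the scatter).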

Compound 3, half-maximal inhibitory concentration: 3.4 nM
For compound 3 the middle estimate is 16-fold (1.21 log units) above the measured one; measured number below the stated range.
By their numbers in this assay, from the lowest: compound 3; then compounds 1 and 2 (each within the scatter of the next).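

Compound 3 shows that this position is far from indifferent: a 16-fold lower number from compound 1 to compound 3 (1.22 log units; beyond the scatter) comes with 4-hydroxyphenyl in place of 3,4-dimethoxyphenyl on a carbon with a double bond to nitrogen. The swap of the whole group on a nitrogen on an aromatic ring gives a 23-fold lower number from compound 2 to compound 3 (1.37 log units; beyond the scatter) and points the same way, a size of effect that compounds 1 and 2 alone could not reveal. Nothing measured here accounts for this gain. Still open, as far as these compounds go, is whether the hydroxyl itself matters, and how a 4-methoxyphenyl or 4-aminophenyl group would compare.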